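Adding a third methoxy to an allyl-bearing triazole amide

This account rests on a few compounds, and the source may have more. Where it says the series, first, only, none or still open, it means among the compounds named here.

Compound 1 `COc1ccc(-c2nnc(SCC(=O)Nc3ccc(/C(C)=N/O)cc3)n2-c2ccccc2)cc1` gives 56% in a functional assay on the whole organism (strain albino) for inhibition, with Rattus norvegicus as the target, read by paw edema, with stated times of 30 min and 2 h, at a dose of 0.28 mmol/kg by the oral route; a lower number here means less inhibition, a higher number more inhibition at the dose given (going by the name of the read-out). Compound 2 `COc1ccc(-c2nnc(SCC(=O)Nc3ccc(/C(C)=N/O)cc3)n2-c2ccccc2)cc1OC` gives 63% in this assay, and compound 3 `C=CCn1c(SCC(=O)Nc2ccc(/C(C)=N/O)cc2)nnc1-c1ccc(OC)c(OC)c1` gives 56% in this assay. The step of a number 7 percentage points higher from compound 1 to compound 2 (within the scatter) came from the change (methoxy in place of hydrogen on an aromatic carbon). The step of a number 7 percentage points lower from compound 2 to compound 3 (within the scatter) followed another change. Compound 4 `C=CCn1c(SCC(=O)Nc2ccc(/C(C)=N/O)cc2)nnc1-c1cc(OC)c(OC)c(OC)c1` is not yet measured. It differs from compound 3 by methoxy in place of hydrogen on an aromatic carbon, the same kind of change as from compound 1 to compound 2, though here the place is also meta to a methoxy group. How the cores of compound 1 and compound 3 differ is not broken down here. Because the earlier step of a number 7 percentage points higher from compound 1 to compound 2 (within the scatter) stayed within the scatter, a step of a number 4 percentage points higher from compound 3 to compound 4 (within the scatter) is expected. Compound 4 is estimated at 60%, between 48% and 72%.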

Compound 4, a percentage reported as inhibition, in the whole organism at one dose (the size of the read-out at that dose, not a potency): 53%
The estimate for compound 4 lay 7 percentage points above the measured number; the measured number falls inside the stated range.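

In this assay, methoxy in place of hydrogen on an aromatic carbon brought a number 3 percentage points lower from compound 3 to compound 4 (within the scatter). Set beside the earlier step on the other core, this shows no difference between the two cores: the same change on two cores in this assay, a number 7 percentage points higher (within the scatter) from compound 1 to compound 2 and a number 3 percentage points lower (within the scatter) from compound 3 to compound 4, 10 percentage points apart, within the scatter of two such steps. Neither step lies beyond the scatter, so the change can be said to carry across these two cores only in leaving the number within the scatter; this does not show that its effect is the same on both, or that a step beyond the scatter would carry over.

The compounds shown leave open whether another group on that aromatic carbon, such as an amine or a longer alkoxy chain, would give a step beyond the scatter. They also leave open how the change would behave on a core with a longer chain in place of the allyl.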